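A few compounds are considered here, and "the series" means these few. Any claim that something is new, unique, unknown or untested is made for them only; others in the source may bear on it.

Three compounds have been measured in a functional assay on HCT-116 cells (Homo sapiens) for antiproliferative activity, read by MTT assay, with a stated time of 72 h; a lower number here means a stronger inhibitor, a higher number a weaker inhibitor:

Compound 1 `CO[C@@H]1C/C=C(\C)C(=O)N(C)[C@@H](C(C)C)C(=O)N[C@H](Cc2ccccc2)C(=O)N[C@@H](C(C)C)C(=O)O[C@H](c2ccccc2)[C@H](C)/C=C/C=C/1C` gives > 100 nM, which is a limit of the assay and not a number.
Compound 2 `CO[C@@H]1C/C=C(\C)C(=O)N(C)[C@@H](C(C)C)C(=O)N[C@H](Cc2cc(Cl)c(O)c(Cl)c2)C(=O)N[C@@H](C(C)C)C(=O)O[C@H](c2ccccc2)[C@H](C)/C=C/C=C/1C` gives 42.1 nM.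
Compound 3 `CC/C1=C\C=C\[C@@H](C)[C@@H](c2ccccc2)OC(=O)[C@H](C(C)C)NC(=O)[C@@H](Cc2cc(Cl)c(O)c(Cl)c2)NC(=O)[C@H](C(C)C)N(C)C(=O)/C(C)=C/C[C@H]1OC` gives 60.3 nM.

Among the two numbers shown, compound 2 has the lowest, but its gap to compound 3, a 1.4-fold higher number from compound 2 to compound 3 (0.16 log units; within the scatter), is within the scatter, so the two cannot be told apart. Compound 4 `CO[C@@H]1C/C=C(\C)C(=O)N(C)[C@@H](C(C)C)C(=O)N[C@H](Cc2ccc(O)cc2)C(=O)N[C@@H](C(C)C)C(=O)O[C@H](c2ccccc2)[C@H](C)/C=C/C=C/1C` is not yet measured. It differs from compound 2 in one place: 4-hydroxyphenyl in place of 3,5-dichloro-4-hydroxyphenyl on a saturated chain carbon bound to a saturated ring carbon. Within the data shown here, the only measured step that bears on this change is the one from the plain phenyl ring to the dichloro-hydroxy ring, an at least 2.3-fold lower number from compound 1 to compound 2 (0.37 log units; beyond the scatter), where compound 1 sits at the limit of > 100 nM in this assay, at which 1 of the 3 values shown sits. Compound 4 keeps the hydroxyl of compound 2 but loses both chlorines, so in structure it lies partway between compound 1 and compound 2. For compound 4 a modest step toward a higher number is expected, a 2.4-fold higher number from compound 2 to compound 4 (0.38 log units; beyond the scatter). Compound 4 is estimated at 100 nM, within 40 nM to 300 nM.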

Compound 4, half-maximal inhibitory concentration: 59.7 nM
Estimate against measurement, compound 4: 1.7-fold (0.22 log units) above; the measured number falls inside the stated range.
By their numbers in this assay, from the lowest: compounds 2, 4 and 3 (each within the scatter of the next). At a limit, above all of these: compound 1.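

In this assay, the 3,5-dichloro-4-hydroxyphenyl and 4-hydroxyphenyl groups at this position, on a saturated chain carbon bound to a saturated ring carbon, cannot be told apart: a 1.4-fold higher number from compound 2 to compound 4 (0.15 log units; within the scatter). The two chlorines are therefore not needed for a value in this range, which the earlier step from the plain phenyl ring to the dichloro-hydroxy ring could not show. Adding the hydroxy group to the phenyl ring gives an at least 1.6-fold lower number from compound 1 to compound 4 (0.22 log units; that floor lies within the scatter), which is only a floor because compound 1 stands at a limit and not at a number: the limit of > 100 nM in this assay, at which 1 of the 4 values shown sits.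

On these data alone, it remains open whether an amine or a methoxy group could take the place of the hydroxy group on this ring. As far as these compounds go, it is also open how a 3,5-dichlorophenyl group, with chlorines but no hydroxy group, would read here.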